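The source may report more compounds than this note shows. Statements on the series, on what has been measured and on what is new or still open speak of the compounds shown alone.

Of the compounds shown here, three built on one shared core have been tested in a functional assay on DU-145 cells (Homo sapiens) for inhibition, read by sulforhodamine B assay, with a stated time of 48 h, tested at 10 uM; on this read-out higher numbers stand for a weaker effect at the one concentration tested and lower numbers for a stronger effect. Compound 1 `COc1cc2cc(Oc3ccc(NC(=O)Nc4ccccc4)cc3)c(C)nc2cc1OC` gives 88.7%, the second highest of the three numbers. Compound 2 `COc1cc2cc(Oc3ccc(NC(=O)Nc4ccc(C)cc4)cc3)c(C)nc2cc1OC` gives 102%, and compound 3 `COc1cc2cc(Oc3ccc(NC(=O)Nc4ccc(C(F)(F)F)cc4)cc3)c(C)nc2cc1OC` gives 71.4%. Three steps link them: a number 13.3 percentage points higher from compound 1 to compound 2 (beyond the scatter) with methyl in place of hydrogen on an aromatic carbon, a number 17.3 percentage points lower from compound 1 to compound 3 (beyond the scatter) with trifluoromethyl in place of hydrogen on an aromatic carbon, and a number 30.6 percentage points lower from compound 2 to compound 3 (beyond the scatter) with trifluoromethyl in place of methyl on an aromatic carbon.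

Compound 4 `COc1cc2cc(Oc3ccc(NC(=O)Nc4ccc(Cl)c(C(F)(F)F)c4)cc3)c(C)nc2cc1OC` differs from compound 1 by 4-chloro-3-(trifluoromethyl)phenyl in place of phenyl on an amide-type nitrogen. Among the measured compounds shown here, of the measured steps, the one from compound 1 to compound 3 matches this change most closely, as both bring in a trifluoromethyl group; the entering group of compound 4 carries chlorine as well, so nothing measured tells how that part adds. A downward step of about the size seen from compound 1 to compound 3, perhaps somewhat larger, is therefore expected, and a number 23.7 percentage points lower from compound 1 to compound 4 (beyond the scatter) is the estimate. Compound 4 is expected to give 65% in this assay, with a range from 45% to 85%.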

Compound 4, a percentage reported as activity, at one concentration (the size of the read-out at that concentration, not a potency): 12.7%
Estimate against measurement, compound 4: 52.3 percentage points above; measured number below the stated range.
By their numbers in this assay, from the lowest: compound 4; then compound 3; then compound 1; then compound 2.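

In this assay, the phenyl on the amide-type nitrogen turns out to allow a far stronger effect than the single-substituent compounds suggested, with a number 76 percentage points lower from compound 1 to compound 4 (beyond the scatter) and a number 89.3 percentage points lower from compound 2 to compound 4 (beyond the scatter) as the steps to compound 4, which has the lowest number of the series. The earlier trifluoromethyl step was only modest, yet the change from 4-(trifluoromethyl)phenyl to 4-chloro-3-(trifluoromethyl)phenyl gives a number 58.7 percentage points lower from compound 3 to compound 4 (beyond the scatter) and so matters more than that step alone implied. No measurement at hand explains why this group has such an effect. The compounds shown do not separate the chlorine from the trifluoromethyl, so it remains open whether 4-chlorophenyl or 3-(trifluoromethyl)phenyl alone would give much of the drop. Going by these compounds, how an amine or a carboxylic acid on this ring would behave also remains open.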